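A few compounds are considered here, and "the series" means these few. Any claim that something is new, unique, unknown or untested is made for them only; others in the source may bear on it.

Working notes on the series. The shared core carries a benzodioxane-type aryl on one side and a piperazine-linked aryl on the other; the compounds differ only in that aryl on the ring nitrogen. In a functional assay on HepG2 cells (Homo sapiens) for antiproliferative activity, read by MTT assay, with a stated time of 48 h (on this read-out higher numbers stand for weaker inhibition and lower numbers for stronger inhibition), compound 1 `S=c1oc(-c2ccc3c(c2)OCCO3)nn1CN1CCN(c2ccc(Cl)cc2)CC1` reads > 50000 nM, which is a limit of the assay and not a number. Compound 2 `COc1ccc(N2CCN(Cn3nc(-c4ccc5c(c4)OCCO5)oc3=S)CC2)cc1` likewise reads > 50000 nM in this assay, again a limit. Compound 3 `S=c1oc(-c2ccc3c(c2)OCCO3)nn1CN1CCN(c2ccccn2)CC1` gives 11400 nM in this assay. Compound 2 therefore stands at the limit, with one of the two other values also sitting there (the limit of > 50000 nM in this assay, at which 2 of the 3 values shown sit). The step that the two limits leave unreadable from compound 1 to compound 2 cannot be read, whereas an at least 4.3-fold lower number from compound 1 to compound 3 (0.64 log units; beyond the scatter) and an at least 4.3-fold lower number from compound 2 to compound 3 (0.64 log units; beyond the scatter) show that exchanging either carbocyclic aryl for pyridin-2-yl brings the number down at least modestly.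

Compound 4 `S=c1oc(-c2ccc3c(c2)OCCO3)nn1CN1CCN(c2cccc(Cl)c2)CC1` is not yet measured. It differs from compound 2 by 3-chlorophenyl in place of 4-methoxyphenyl on an amine nitrogen in a ring. Only the unreadable step from compound 1 to compound 2 bears directly on swapping one carbocyclic aryl for another, and both of those compounds sit at the limit; compound 4 keeps a carbocyclic aryl and so is expected to stay near the limit, with a step that the limit leaves unreadable from compound 2 to compound 4 expected to be no step beyond the scatter. For compound 4 the expected value in this assay is 60000 nM, within the range 20000 nM to 180000 nM, most likely reported again only as a limit.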

Compound 4, half-maximal inhibitory concentration: > 50000 nM
Compound 4: no number, only a limit; the forecaster's own chance of this, stated with the estimate: 65%; the middle value is on the limit's open side.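

The value of compound 4 in this assay, > 50000 nM, is a limit of the assay and not a number. With 3-chlorophenyl in place of pyridin-2-yl on the amine nitrogen in the ring, the result is an at least 4.3-fold higher number from compound 3 to compound 4 (0.64 log units; beyond the scatter), so a third carbocyclic aryl now contrasts with compound 3, and among the four compounds only compound 3 gives a number and not a limit. The steps among compound 1, compound 2 and compound 4 cannot be read, so moving the chloro group from the 4-chlorophenyl to the 3-chlorophenyl pattern and exchanging 4-methoxyphenyl for 3-chlorophenyl show no size or direction, and these three aryl groups cannot be ranked: the limit of > 50000 nM in this assay, at which 3 of the 4 values shown sit.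

Every carbocyclic aryl shown carries a substituent while pyridin-2-yl carries none, so the compounds leave open whether the lower number of compound 3 goes with the ring nitrogen of the pyridine or with the absence of a chloro or methoxy group. Unsubstituted phenyl and pyrimidinyl on the same amine nitrogen would separate these two readings, and a chloro-substituted pyridine would test whether they combine.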